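The compounds below may be only part of what the source reports. "The series", "measured", "known", "first", "only" and "open" are said of these compounds alone.

Measured so far:
- compound 1, `Cn1ncc2cc(-c3cnccc3/C=C/C(=O)O)ccc21`: > 10000 nM
- compound 2, `Cn1ccc2cc(-c3cnccc3/C=C/C(=O)O)ccc21`: > 10000 nM
- compound 3, `CNC(=O)/C=C/c1ccncc1-c1ccc2c(ccn2C)c1`: 6450 nM

All values come from a functional assay on A549 cells (Homo sapiens) for inhibition, read by sulforhodamine B assay, with a stated time of 72 h; a higher number here means a weaker inhibitor of growth, a lower number a stronger inhibitor of growth. For compound 1 the value > 10000 nM is a limit of the assay, not a number. For compound 2 the value > 10000 nM is likewise a limit. Compound 3 gives a number, 6450 nM, in this assay.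

Compound 2 and compound 3 share a core and differ by methylamino in place of hydroxy on a carbonyl carbon. The measured step is an at least 1.5-fold lower number from compound 2 to compound 3 (0.19 log units; that floor lies within the scatter); it can only be given as a floor because of the limit of > 10000 nM in this assay, at which 2 of the 3 values shown sit.

Compound 4, `CNC(=O)/C=C/c1ccncc1-c1ccc2c(cnn2C)c1`, is not yet measured. It stands to compound 1 as compound 3 stands to compound 2: the change is methylamino in place of hydroxy on a carbonyl carbon, and it sits on the same kind of place in both pairs, a carbonyl carbon whose other neighbour is a double-bonded chain carbon, so it is the same change. The cores of compound 1 and compound 2 differ, but that difference is not broken down here.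

One measured instance of the change is a thin basis, and it rests on a floor. The expected outcome is that compound 4 moves in the same direction and by a similar or smaller amount, with a real chance that the assay again reports only a limit. Compound 4 is expected at 8000 nM, within a range of 3000 nM to 20000 nM. The expected step is an at least 1.2-fold lower number from compound 1 to compound 4 (0.09 log units; that floor lies within the scatter), set beside an at least 1.5-fold lower number from compound 2 to compound 3 (0.19 log units; that floor lies within the scatter).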

Compound 4, concentration for 50% growth inhibition: > 10000 nM
Compound 4 was reported as a limit; the forecaster's own chance of this, stated with the estimate: 45%; middle value at least 1.2-fold (0.09 log units) from the limit.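

Compound 4 gives > 10000 nM, a limit of the assay and not a number. Compound 1 gives > 10000 nM, also a limit. No step from compound 1 to compound 4 can be read because both sit at that limit: the limit of > 10000 nM in this assay, at which 3 of the 4 values shown sit.

The compounds shown leave open whether methylamino in place of hydroxy on a carbonyl carbon changes growth inhibition at all on the core of compound 1.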